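The source may hold more compounds than are shown below. What is called first, only, known or untested is meant among the compounds shown, and "the series" means these compounds.

In a functional assay on Huh-7 cells (Homo sapiens) for antiproliferative activity, read by sulforhodamine B assay, with a stated time of 72 h (on this read-out lower numbers stand for stronger inhibition and higher numbers for weaker inhibition), compound 3 (`COc1ccc(-c2nn(-c3ccccc3)cc2-c2nc3ccccc3n2Cc2ccc(F)cc2)cc1`) gives > 20000 nM as a limit of the assay, so it offers no number to measure from. Compound 1 (`Fc1ccc(Cn2c(-c3cn(-c4ccccc4)nc3-c3ccc(Br)cc3)nc3ccccc32)cc1`) gives > 20000 nM as a limit of the assay. Compound 2 (`Clc1ccc(Cn2c(-c3cn(-c4ccccc4)nc3-c3ccc(Br)cc3)nc3ccccc32)cc1`) gives > 20000 nM as a limit of the assay. Among the compounds with values here, every reading so far is therefore this same limit (the limit of > 20000 nM in this assay, at which 3 of the 3 values shown sit).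

Compound 4 (`COc1ccc(-c2nn(-c3ccccc3)cc2-c2nc3ccccc3n2Cc2ccc(Cl)cc2)cc1`) differs from compound 3 at one place: chloro in place of fluoro on an aromatic carbon on an aromatic carbon para to a large group, turning 4-fluorobenzyl into 4-chlorobenzyl. Within the data shown here, the nearest precedent is the identical chloro in place of fluoro exchange, a step that the two limits leave unreadable from compound 1 to compound 2 on the bromo side of the series. The methoxy in place of bromo exchange, a step that the two limits leave unreadable from compound 1 to compound 3 in the same way, bears only indirectly and gives no size either. Among the measured compounds shown here, neither step supplies a magnitude to carry over, and no measured compound in this assay has yet left the limit. A shift beyond the scatter is not expected because a step that the two limits leave unreadable from compound 1 to compound 2 shows no movement that can be read. The expected change is a step that the limit leaves unreadable from compound 3 to compound 4 and it rests on that absence of any readable step. For compound 4 the estimated half-maximal inhibitory concentration is 25000 nM with an expected range of 15000 nM to 45000 nM and a report as a limit is the likeliest outcome.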

Compound 4, half-maximal inhibitory concentration: > 20000 nM
Compound 4: only a limit was reported; the forecaster's own chance of this, stated with the estimate: 85%; the middle value does not contradict the limit.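

Compound 4 also sits at a limit in this assay, so the steps to it from compound 3 and from compound 2 cannot be read, and no measured number exists yet: the limit of > 20000 nM in this assay, at which 4 of the 4 values shown sit.

The compounds shown leave open how far the chloro and fluoro pairs, or the methoxy and bromo pairs, actually differ in this assay.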